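The source may hold more compounds than are shown below. What is called first, only, known or untested is meant among the compounds shown, and "the series" means these compounds.

Working notes on the series, tested in a functional assay on MCF7 cells (Homo sapiens) for antiproliferative activity, read by MTT assay, with a stated time of 72 h; a higher number here means a weaker inhibitor, a lower number a stronger inhibitor. Compound 1 `CC1=CC[C@H]2[C@H](CC[C@]2(C)O)C(C)(C)[C@@H]1CC[C@H]1[C@]2(C)CC[C@H](OC(=O)CCC(=O)O)C(C)(C)O[C@H]2CC[C@@]1(C)O` gives only a limit, > 50000 nM. Going by the values given here, compound 2 `CC(=O)O[C@H]1CC[C@]2(C)[C@H](CC[C@@](C)(O)[C@H]2CC[C@@H]2C(C)=CC[C@@H]3C(C)=CC[C@@H]3C2(C)C)OC1(C)C` gives 43500 nM, the sole actual number so far, so there is no second number to rank it against. Compound 3 `CC1=CC[C@H]2[C@@H]1CC=C(C)[C@@H](CC[C@H]1[C@]3(C)CC[C@H](OC(=O)c4ccc(C)cc4)C(C)(C)O[C@H]3CC[C@@]1(C)O)C2(C)C` keeps the shared core and differs from compound 2 in one place: 4-methylphenyl in place of methyl on a carbonyl carbon. Among the compounds with values here, no step between measured compounds is available to calibrate this change, so its size remains a rough expectation. Starting from compound 2 at 43500 nM, a small move toward a lower number in this assay is expected, hardly beyond the scatter. A result for compound 3 reported only as a limit remains possible. The expected step is a 1.5-fold lower number from compound 2 to compound 3 (0.16 log units; within the scatter). For compound 3 the estimated value is 30000 nM, with an expected range of 10000 nM to 60000 nM.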

Compound 3, half-maximal inhibitory concentration: > 50000 nM
Compound 3: no number, only a limit; the forecaster's own chance of this, stated with the estimate: 35%; middle value at least 1.6-fold (0.22 log units) away from the limit.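

In this assay, 4-methylphenyl in place of methyl on a carbonyl carbon gives an at least 1.1-fold higher number from compound 2 to compound 3 (0.06 log units; that floor lies within the scatter). Compound 3 gives > 50000 nM, which is a limit of the assay and not a number. The change from acetoxy to ((4-methylphenyl)carbonyl)oxy therefore gives no lower number at this position, and its true size cannot be read, with a single actual number available in the series and the rest at the limit: the limit of > 50000 nM in this assay, at which 2 of the 3 values shown sit.

On these data alone, whether an amine or a longer chain in place of methyl on this carbonyl carbon would give a number clear of the limit remains open. Going by these compounds alone, with compound 2 as the only compound carrying an actual number, no trend at this position can yet be described.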